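The source may report more compounds than this note shows. Statements on the series, on what has been measured and on what is new or still open speak of the compounds shown alone.

Measured so far:
Compound 1 `CCCCn1c(=N)sc2cc(OC(F)(F)F)ccc21` — in a functional assay on the whole organism with Rattus norvegicus as the target (a lower number here means that less compound is needed, a higher number that more compound is needed for the effect), compound 1 gives 10 mg/kg.
Compound 2 `N=c1sc2cc(OC(F)(F)F)ccc2n1Cc1ccccc1` — in this assay compound 2 reaches only a limit of the assay, > 10 mg/kg.
Compound 3 `N=c1sc2cc(OC(F)(F)F)ccc2n1CCO` — in this assay compound 3 gives 8 mg/kg.

Compound 3 holds the lowest of the two numbers; compound 1 is nearest, and a 1.3-fold lower number from compound 1 to compound 3 (0.10 log units; within the scatter) lies within the scatter. Compound 4 `N=c1sc2cc(OC(F)(F)F)ccc2n1CCSc1ccccc1` differs from compound 3 by phenylsulfanyl in place of hydroxy on a saturated chain carbon, two bonds along the chain from an aromatic nitrogen. Among the measured compounds shown here, two measured steps bear on bringing an aromatic ring onto the chain: an at least 1.2-fold lower number from compound 2 to compound 3 (0.09 log units; that floor lies within the scatter), and a number no lower from compound 1 to compound 2 (the limit leaves the size open), the latter fixed by the limit of > 10 mg/kg in this assay, at which 1 of the 3 values shown sits. Both point toward a higher number, so compound 4 is expected to need more, and may again end at the limit. For compound 4 in this assay the estimate is 16 mg/kg, range 6 mg/kg to 45 mg/kg, meaning an expected step of a 2.0-fold higher number from compound 3 to compound 4 (0.30 log units; within the scatter).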

Compound 4, dose for half-maximal effect: 4.5 mg/kg
Estimate against measurement, compound 4: 3.6-fold (0.55 log units) above; measured number below the stated range.
By their numbers in this assay, from the lowest: compounds 4, 3 and 1 (each within the scatter of the next, the first and the last beyond it).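

Among the compounds shown here, on the saturated chain carbon, phenylsulfanyl brings an aromatic ring without a higher number in this assay: a 2.2-fold lower number from compound 1 to compound 4 (0.35 log units; beyond the scatter) is the only step between two exact numbers beyond the scatter, while a 1.8-fold lower number from compound 3 to compound 4 (0.25 log units; within the scatter) leaves phenylsulfanyl and hydroxy unresolved. The ring's linkage appears to count, with an at least 2.2-fold lower number from compound 2 to compound 4 (0.34 log units; beyond the scatter) for (phenylsulfanyl)methyl in place of phenyl. That step rests on compound 2, whose value is a limit: the limit of > 10 mg/kg in this assay, at which 1 of the 4 values shown sits.

The compounds shown do not separate the sulfur from the ring. Going by these compounds, how phenoxy or an amine would read at this place stays open.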